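From 2-Methoxyphenyl to 4-Methoxy-3-methylphenyl

The source may hold more compounds than are shown below. What is called first, only, known or untested is meant among the compounds shown, and "the series" means these compounds.

In a functional assay on HL-60 cells (Homo sapiens) for antiproliferative activity, read by MTT assay, with a stated time of 72 h (on this read-out higher numbers stand for weaker inhibition and lower numbers for stronger inhibition), compound 1 `COc1cc(C(=O)c2sc3ccccc3c2-c2ccccc2)cc(OC)c1OC` gives 1700 nM and compound 2 `COc1ccccc1-c1c(C(=O)c2cc(OC)c(OC)c(OC)c2)sc2ccccc12` gives 2900 nM. These two values lie within the scatter of each other, which is all that can be said of where compound 2 stands. Compound 3 `COc1ccc(-c2c(C(=O)c3cc(OC)c(OC)c(OC)c3)sc3ccccc23)cc1C` changes one group of compound 2: 4-methoxy-3-methylphenyl in place of 2-methoxyphenyl on an aromatic carbon. Within the data shown here, the only measured step, a 1.7-fold higher number from compound 1 to compound 2 (0.23 log units; within the scatter), places a methoxy in place of hydrogen and stays within the scatter. It is a weak guide, so the expectation stays loose, leaning toward a lower number. The expected change is a 3.6-fold lower number from compound 2 to compound 3 (0.56 log units; beyond the scatter). For compound 3 the estimate is 800 nM, with a range of 100 nM to 3500 nM.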

Compound 3, half-maximal inhibitory concentration: > 10000 nM
Compound 3: only a limit was reported (the forecaster's own chance of this, stated with the estimate: 3%); middle value at least 12-fold (1.09 log units) from the limit.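

Replacing 2-methoxyphenyl with 4-methoxy-3-methylphenyl gives an at least 3.4-fold higher number from compound 2 to compound 3 (0.53 log units; beyond the scatter), and replacing phenyl with it gives an at least 5.8-fold higher number from compound 1 to compound 3 (0.76 log units; beyond the scatter). So, unlike the methoxy step between the earlier compounds, a change at this aromatic carbon can move the number beyond the scatter, toward weaker inhibition in this assay. The reading for compound 3 is a limit, not a number: the limit of > 10000 nM in this assay, at which 1 of the 3 values shown sits.

Which part of the entering group, the methoxy or the methyl, goes with the weaker inhibition stays open. So does how an amine in place of that methyl would read.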